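The source may hold more compounds than are shown below. What is called first, only, known or untested is meant among the compounds shown, and "the series" means these compounds.

Compound 1 `COc1ccc2ncc(S(=O)(=O)c3ccc(C)cc3)c(N3CCC(C)CC3)c2c1` gives 90% in an assay on isolated protein for displacement of a labelled ligand from metabotropic glutamate receptor 5 (Homo sapiens), with a stated time of 60 min, tested at 1 uM (on this read-out lower numbers stand for less inhibition and higher numbers for more inhibition at the one concentration tested (going by the name of the read-out)), the higher of the two numbers measured. Within the data shown here, compound 2 `Cc1ccc(S(=O)(=O)c2cnc3ccc(C)cc3c2N2CCC(C)CC2)cc1` gives 82% in this assay, and the only measured step, a number 8 percentage points lower from compound 1 to compound 2 (within the scatter), concerns a change on the shared core rather than on the sulfonyl aryl. Compound 3 `COc1ccc2ncc(S(=O)(=O)c3ccc(OC)c(OC)c3)c(N3CCC(C)CC3)c2c1` differs from compound 1 by 3,4-dimethoxyphenyl in place of 4-methylphenyl on a sulfonyl sulfur. Among the measured compounds shown here, no measured step bears on this change, so no firm direction can be drawn; a modest loss is expected, a number 15 percentage points lower from compound 1 to compound 3 (beyond the scatter), with a wide range. Compound 3 is therefore estimated at 75%, between 40% and 95%.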

Compound 3, a percentage reported as inhibition, at one concentration (the size of the read-out at that concentration, not a potency): -3%
Compound 3: the middle estimate sits 78 percentage points above what was measured, outside the stated range (below it).
By their numbers in this assay, from the lowest: compound 3; then compounds 2 and 1 (each within the scatter of the next).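

In this assay the change to 3,4-dimethoxyphenyl in place of 4-methylphenyl on a sulfonyl sulfur gives a number 93 percentage points lower from compound 1 to compound 3 (beyond the scatter) and shows that inhibition depends strongly on the aryl group at this position, whereas the earlier step on the shared core stayed within the scatter. Nothing available explains this loss. Going by these compounds, it remains open whether a single methoxy group on the phenyl ring would cause the same loss, and whether an unsubstituted phenyl or a 4-fluorophenyl on the sulfonyl sulfur would retain the inhibition.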